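The compounds below may be only part of what the source reports. "The series", "measured", "known", "first", "only" and "open" are said of these compounds alone.

Compound 1, with structure `CCOC(=O)COn1c(-c2cccc(C#N)c2)nc(C)c1C(=O)OCC`, is a good place to start. Among the compounds with values here, in a functional assay on a cell-free system (plasma, Oryctolagus cuniculus) for inhibition, with stated times of 5 min, 1 min and 6 min (on this read-out lower numbers stand for stronger inhibition and higher numbers for weaker inhibition), compound 1 gives 6800 nM, the second highest of the three numbers measured so far. Its closest neighbour is compound 2, `CCOC(=O)c1c(C)nc(-c2cccc(C#N)c2)n1OCc1ccncc1`, which in this assay gives 6200 nM; the step of a 1.1-fold lower number from compound 1 to compound 2 (0.04 log units; within the scatter) does not pass the usual scatter. Compound 3, `CCOC(=O)c1c(C)nc(-c2cccc(C#N)c2)n1OCc1ccc(Br)cc1`, gives 24600 nM in this assay, and the step of a 3.6-fold higher number from compound 1 to compound 3 (0.56 log units; beyond the scatter) does pass it.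

Compound 4, `CCOC(=O)c1c(C)nc(-c2cccc(C#N)c2)n1OCc1ccc(C(=O)OC)cc1`, has not been measured. It differs from compound 1 in one place: 4-(methoxycarbonyl)phenyl in place of ethoxycarbonyl on a saturated chain carbon bound to an oxygen on an aromatic ring. The incoming group is a six-membered aromatic ring of carbon only, carrying a methoxycarbonyl group, and it sits at the same place where compound 2 carries pyridin-4-yl and compound 3 carries 4-bromophenyl. Those two rings at that place gave opposite lessons: the pyridin-4-yl of compound 2 left the number essentially unchanged, while the 4-bromophenyl of compound 3 raised it modestly, and between the two rings the step of a 4.0-fold higher number from compound 2 to compound 3 (0.60 log units; beyond the scatter) is also modest. A ring at this place therefore seems to cost little or a modest amount, never to help. For compound 4 a slight weakening is expected, a 1.6-fold higher number from compound 1 to compound 4 (0.21 log units; within the scatter), so the estimate is 11000 nM, with a range from 4500 nM to 28000 nM.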

Compound 4, half-maximal inhibitory concentration: 9470 nM
Compound 4: middle estimate off by 1.2-fold (0.07 log units), on the high side; low and high end bracket the measured number.
By their numbers in this assay, from the lowest: compounds 2, 1 and 4 (each within the scatter of the next); then compound 3.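

Within this assay, the change of bromo to methoxycarbonyl on an aromatic carbon gives a 2.6-fold lower number from compound 3 to compound 4 (0.41 log units; beyond the scatter), so the number at this place depends on what the six-membered carbon ring carries, not just on the ring being there. The 4-(methoxycarbonyl)phenyl group, with 10 heavy atoms against 5 for ethoxycarbonyl, also stays within the scatter of both earlier groups, with a 1.4-fold higher number from compound 1 to compound 4 (0.14 log units; within the scatter) and a 1.5-fold higher number from compound 2 to compound 4 (0.18 log units; within the scatter), so a larger group at this place need not move the number, although the 4-bromophenyl of compound 3 goes against any rule that all such rings are tolerated. Nothing available explains why methoxycarbonyl and bromo on the ring differ in this way.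

Going by these compounds, with only these two groups on that ring, it remains open whether a carboxylic acid or an amine at the same carbon would give a number like that of compound 4 or that of compound 3. On these data alone, it is equally open how a plain phenyl ring or a longer chain would behave on the saturated chain carbon bound to the oxygen.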